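The source may hold more compounds than are shown below. What is called first, only, known or untested is meant among the compounds shown, and "the series" means these compounds.

- compound 1 `Cc1cc2c(c(=O)n1C)C(c1ccc(F)c(Br)c1)C(C#N)=C(N)O2` gives 6330 nM
- compound 2 `Cc1cc2c(c(=O)n1C)C(c1cccc(Br)c1)C(C#N)=C(N)O2` gives 6500 nM

These values come from a functional assay on HeLa cells (Homo sapiens) for antiproliferative activity, read by MTT assay, with a stated time of 48 h; on this read-out lower numbers stand for stronger inhibition and higher numbers for weaker inhibition. Among the compounds with values here, compound 1, the only other compound measured, stands level with compound 2 at 6500 nM. Compound 3 `Cc1cc2c(c(=O)n1C)C(c1ccc(Cl)c(Cl)c1)C(C#N)=C(N)O2` has 3,4-dichlorophenyl in place of 3-bromophenyl on a saturated ring carbon. Within the data shown here, one measured step bears on this change, and only loosely: a 1.0-fold higher number from compound 1 to compound 2 (0.01 log units; within the scatter), which swaps a halogen on the same kind of aromatic ring. That single step gives no reason to expect a shift beyond the scatter in this assay, in either direction. The expected step is a 1.1-fold lower number from compound 2 to compound 3 (0.03 log units; within the scatter). Compound 3 is estimated at 6000 nM, with an expected range from 2500 nM to 14000 nM.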

Compound 3, half-maximal inhibitory concentration: 18300 nM
The estimate for compound 3 lay 3.1-fold (0.48 log units) below the measured number; the whole stated range lies below it.
By their numbers in this assay, from the lowest: compounds 1 and 2 (each within the scatter of the next); then compound 3.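

In this assay, replacing 3-bromophenyl with 3,4-dichlorophenyl on the saturated ring carbon gives a 2.8-fold higher number from compound 2 to compound 3 (0.45 log units; beyond the scatter) and replacing 3-bromo-4-fluorophenyl with it gives a 2.9-fold higher number from compound 1 to compound 3 (0.46 log units; beyond the scatter). So this position does respond to some changes in the halogens on the aromatic ring, which the earlier pair, level within the scatter, did not show. No measurement available here explains the shift. The compounds shown leave open whether a single chlorine accounts for the shift, and how a methoxy or dimethylamino group on this ring would compare.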